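Swapping the vinyl for an amino-hydroxyethyl arm

This account rests on a few compounds, and the source may have more. Where it says the series, first, only, none or still open, it means among the compounds named here.

In a toxicity assay on the whole organism (J774 cells) for cytotoxicity, with Mus musculus as the target, read by MTT assay, with a stated time of 24 h, tested at 10 uM (on this read-out higher numbers stand for a weaker effect at the one concentration tested and lower numbers for a stronger effect), compound 2 `C=CCO[C@H]1O[C@H](CN)[C@@H](OCCCCCCCCC)[C@H](OCCCCCCCCC)[C@H]1N` gives 91.4%, the lowest of the two numbers shown, with its nearest neighbour compound 1 `CCCCCCCCCO[C@@H]1[C@@H](N)[C@@H](OCC(O)CNCCO)O[C@H](CN)[C@H]1OCCCCCCCCC` at 99.1%. Among the measured compounds shown here, the only measured step, a number 7.7 percentage points lower from compound 1 to compound 2 (within the scatter), swaps a polar arm for vinyl. Compound 3 `CCCCCCCCCO[C@@H]1[C@@H](N)[C@@H](OC[C@H](O)CN)O[C@H](CN)[C@H]1OCCCCCCCCC` reverses that kind of change: 2-amino-1-hydroxyethyl in place of vinyl on a saturated chain carbon bound to an oxygen on a saturated carbon. Since that step stayed within the scatter, no step beyond the scatter is expected in this assay either, and the expected step is a number 4.6 percentage points higher from compound 2 to compound 3 (within the scatter). Compound 3 is therefore estimated at 96%, with a range from 86% to 102%.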

Compound 3, a percentage reported as activity, at one concentration (the size of the read-out at that concentration, not a potency): 88%
The estimate for compound 3 lay 8 percentage points above the measured number, within the range that was stated.
By their numbers in this assay, from the lowest: compounds 3, 2 and 1 (each within the scatter of the next, the first and the last beyond it).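

At this place in this assay, the arm attached to the shared core now produces a step beyond the scatter, though only between the two amino-bearing arms: 2-amino-1-hydroxyethyl gives a modestly stronger effect than 1-hydroxy-2-((2-hydroxyethyl)amino)ethyl (a number 11.1 percentage points lower from compound 1 to compound 3 (beyond the scatter)). Exchanging vinyl for 2-amino-1-hydroxyethyl does not separate the compounds (a number 3.4 percentage points lower from compound 2 to compound 3 (within the scatter)). No available measurement accounts for either step.

Still open, from the compounds shown here alone, is how a carboxylic acid, a guanidine or a longer aminoalkyl chain at this place would read in this assay.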